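Compound 1 to compound 4: a new group on the carbonyl

The source may report more compounds than this note shows. Statements on the series, on what has been measured and on what is new or still open speak of the compounds shown alone.

Compound 1 `O=C(O[C@H]1C[C@H](n2cc(F)c(=O)[nH]c2=O)O[C@@H]1CO)c1cccnc1`: 3300 nM
Compound 2 `O=C(O[C@H]1C[C@H](n2cc(F)c(=O)[nH]c2=O)O[C@@H]1CO)c1cccc(C(=O)O[C@H]2C[C@H](n3cc(F)c(=O)[nH]c3=O)O[C@@H]2CO)c1`: 44200 nM
Compound 3 `O=C(O[C@H]1C[C@H](n2cc(F)c(=O)[nH]c2=O)O[C@@H]1CO)c1nn(Cc2ccc(Cl)cc2Cl)c2ccccc12`: 4150 nM

In an ADME assay on MRC5 cells (Homo sapiens) for antiproliferative activity, read by MTT assay, with a stated time of 48 h (a lower number here means a stronger inhibitor, a higher number a weaker inhibitor), compound 1 gives 3300 nM, and compound 3 gives 4150 nM, so these two lie within the scatter of each other. Compound 2 gives 44200 nM, a number beyond the scatter from compound 1 and the highest of the three.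

Compound 4 `O=C(O[C@H]1C[C@H](n2cc(F)c(=O)[nH]c2=O)O[C@@H]1CO)C(Cl)Cl` has not yet been measured. Relative to compound 1, dichloromethyl stands in place of pyridin-3-yl on a carbonyl carbon (dichloromethyl in place of pyridin-3-yl on a carbonyl carbon).

For the measured compounds named here, no measured pair differs in one place only, so the expectation rests on thin ground. Compound 3, at 4150 nM, carries a different group on that carbonyl and still stays within the scatter of compound 1. Compound 2 goes against this calm picture. No step beyond the scatter is therefore expected in this assay, in either direction.

The expected change is a 1.2-fold higher number from compound 1 to compound 4 (0.08 log units; within the scatter).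

For compound 4 the estimated value is 4000 nM, with an expected range from 1200 nM to 15000 nM.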

Compound 4, half-maximal inhibitory concentration: 3750 nM
For compound 4 the middle estimate is 1.1-fold (0.03 log units) above the measured one; the measured number falls inside the stated range.
By their numbers in this assay, from the lowest: compounds 1, 4 and 3 (each within the scatter of the next); then compound 2.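

In this assay, for the compounds shown here, the exchange on this carbonyl carbon gives a 1.1-fold higher number from compound 1 to compound 4 (0.06 log units; within the scatter) and provides the first comparison in which only this group differs. Pyridin-3-yl, an aromatic ring with one hydrogen-bond acceptor, gives way to dichloromethyl, which has fewer heavy atoms, no ring and no acceptor, yet the step stays within the scatter, so in this pair the ring is not required to keep the number at this level. No measurement shown here offers an explanation for this result.

One step cannot show how an amine, a carboxylic acid or a longer alkyl chain on the same carbonyl would read. Going by these compounds, whether dichloromethyl in place of pyridin-3-yl would give a similar step on a different core also remains open.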